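The compounds below may be only part of what the source reports. "The series", "measured", "known", "first", "only" and "open" are said of these compounds alone.

Measured compounds:
Compound 1 `CCOC(=O)[C@@H]1CCCN(S(=O)(=O)c2ccc(S(=O)(=O)N3CCCCC3)cc2)C1` gives 1000 nM in a functional assay on MIA PaCa-2 cells (Homo sapiens) for inhibition, read by MTT assay, with a stated time of 3 days; on this read-out lower numbers stand for stronger inhibition and higher numbers for weaker inhibition.
Compound 2 `CCN(CC)S(=O)(=O)c1ccc(S(=O)(=O)N2CCC[C@@H](C(=O)N3CCN(c4nnc(C(C)C)o4)CC3)C2)cc1` gives 1000 nM in this assay.
Compound 3 `CCOC(=O)N1CCC[C@@H](S(=O)(=O)c2ccc(S(=O)(=O)N(CC)CC)cc2)C1` gives > 10000 nM in this assay, which is a limit of the assay and not a number.

Compound 1 stands level with compound 2, the value nearest to it, and the two are within the usual scatter of each other, so neither can be called the more potent. Compound 3 is the one entry that is only a limit (the limit of > 10000 nM in this assay, at which 1 of the 3 values shown sits). Compound 2 differs from compound 1 in more than one place, so setting its value beside that of compound 1 shows only that the two are level.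

Compound 4 `CCOC(=O)[C@@H]1CCCN(S(=O)(=O)c2ccc(S(=O)(=O)N(CC)C(C)C)cc2)C1` has not yet been measured in this assay. It differs from compound 1 in one place: ethyl(isopropyl)amino in place of piperidin-1-yl on a sulfonyl sulfur. For the measured compounds named here, no pair of measured compounds isolates this change, so its size cannot be read from the data. The step expected from compound 1 to compound 4 is a 1.2-fold higher number from compound 1 to compound 4 (0.08 log units; within the scatter), that is, none beyond the scatter. Compound 4 is accordingly expected to give about 1200 nM in this assay, with a range of 500 nM to 3000 nM.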

Compound 4, half-maximal inhibitory concentration: 1200 nM
The estimate for compound 4 equals the measured number at the digits printed; the measured number falls inside the stated range.
By their numbers in this assay, from the lowest: compounds 1, 2 and 4 (each within the scatter of the next). At a limit, above all of these: compound 3.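

In this assay, ethyl(isopropyl)amino in place of piperidin-1-yl on a sulfonyl sulfur gives a 1.2-fold higher number from compound 1 to compound 4 (0.08 log units; within the scatter), so at this place a group with no ring serves as well as the six-membered non-aromatic ring of compound 1. This is the first pair shown that differs in one place only; the earlier compounds differ from one another in more than one place and could not show what this position alone does. Nothing measured here accounts for the two values being level.

As far as these compounds go, both groups compared hold only carbon and one nitrogen, so it remains open whether a morpholine, a small primary amine or a chain ending in a carboxylic acid on the same sulfonyl sulfur would give a number beyond the scatter of compound 1. It also remains open how much the ethyl ester of the core of compound 1 contributes, as neither a carboxylic acid nor a longer alkyl ester in its place appears among the compounds shown.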